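The source may hold more compounds than are shown below. What is called first, only, known or untested is meant among the compounds shown, and "the series" means these compounds.

Among the three compounds measured in an assay on HEK293 cells for inhibition of kynurenine 3-monooxygenase (Homo sapiens), read by LC-MS, with a stated time of 20 h (a lower number here means a stronger inhibitor, a higher number a weaker inhibitor), compound 3 `CCc1cc2oc(=O)n(CCC(=O)O)c2cc1Cl` gives the lowest number, 316 nM. Compound 2 `O=C(O)CCn1c(=O)oc2cc(OCC3CCC3)c(Cl)cc21` gives 1260 nM and compound 1 `COCCOc1cc2oc(=O)n(CCC(=O)O)c2cc1Cl` gives 50100 nM; the step of a 4.0-fold lower number from compound 2 to compound 3 (0.60 log units; beyond the scatter) is modest, while a 160-fold lower number from compound 1 to compound 3 (2.20 log units; beyond the scatter) and a 40-fold lower number from compound 1 to compound 2 (1.60 log units; beyond the scatter) are large. Compound 4 `O=C(O)CCn1c(=O)oc2cc(Cl)c(Cl)cc21` differs from compound 3 in one place: chloro in place of ethyl on an aromatic carbon.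

All three measured steps concern the same aromatic carbon, and in each of them a shorter substituent brought a lower number, the three replacements being ether chains of differing length and a two-carbon ethyl. Within the data shown here, no measured pair compares chloro with ethyl, so the size of this step is not directly anchored. Among the measured compounds shown here, since a chloro is the smaller group and the earlier steps moved in the same direction, the step is expected to be small and within the scatter or slightly favourable, as a 1.6-fold lower number from compound 3 to compound 4 (0.20 log units; within the scatter) expresses. On that basis compound 4 is estimated at 200 nM, with a range from 50 nM to 800 nM.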

Compound 4, half-maximal inhibitory concentration: 2000 nM
Compound 4: middle estimate off by 10-fold (1.00 log units), on the low side; measured number above the stated range.
By their numbers in this assay, from the lowest: compound 3; then compounds 2 and 4 (each within the scatter of the next); then compound 1.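

With a 6.3-fold higher number from compound 3 to compound 4 (0.80 log units; beyond the scatter) the run in which a shorter substituent gave a lower number at this aromatic carbon breaks: compound 4 goes against it, since chloro has 1 heavy atom and ethyl has 2. The number at this position therefore does not follow substituent size alone among the compounds shown, and ethyl is the only group here that gives a clear gain over chloro. The step of a 1.6-fold higher number from compound 2 to compound 4 (0.20 log units; within the scatter) lies within the scatter, so chloro and cyclobutylmethoxy cannot be told apart here, whereas a 25-fold lower number from compound 1 to compound 4 (1.40 log units; beyond the scatter) sets 2-methoxyethoxy far from chloro.

Nothing available explains the gap between ethyl and chloro. On these data alone, it remains open how a methyl, a propyl or an amine on this aromatic carbon would compare with ethyl.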